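The compounds below may be only part of what the source reports. "The series", "measured", "known", "first", "only" and "open" are said of these compounds alone.

Working notes on the series. In a functional assay on MCF7 cells (Homo sapiens) for cytotoxicity, read by MTT assay, with a stated time of 72 h (a higher number here means a weaker inhibitor, a lower number a stronger inhibitor), compound 1 `O=C1c2c[n+]([O-])c3ccccc3c2C(=O)c2c1c1ccccc1n2Cc1cn([C@H]2O[C@H](CO)[C@@H](O)[C@H]2O)nn1` gives 1490 nM. Compound 2 `O=C1c2c[n+]([O-])c3ccccc3c2C(=O)c2c1c1ccccc1n2Cc1cn(C[C@H](O)CO)nn1` gives > 1000 nM, which is a limit. Compound 3 `CC1(C)OC[C@@H](Cn2cc(Cn3c4c(c5ccccc53)C(=O)c3c[n+]([O-])c5ccccc5c3C4=O)nn2)O1` gives > 1000 nM, also a limit, so it has no number and stands at the limit of > 1000 nM in this assay, at which 2 of the 3 values shown sit.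

The next structure is compound 4 `O=C1c2c[n+]([O-])c3ccccc3c2C(=O)c2c1c1ccccc1n2Cc1cn([C@H]2C[C@H](O)[C@@H](CO)O2)nn1`, with the change (4-hydroxy-5-(hydroxymethyl)oxolan-2-yl in place of (2,2-dimethyl-1,3-dioxolan-4-yl)methyl on an aromatic nitrogen), made on an aromatic nitrogen.

Going by the values given here, the steps that bear on this change are a step that the limit leaves unreadable from compound 1 to compound 3, a step that the limit leaves unreadable from compound 1 to compound 2 and a step that the two limits leave unreadable from compound 2 to compound 3. None has a readable size, so none can be carried over. Among the compounds with values here, the entering 4-hydroxy-5-(hydroxymethyl)oxolan-2-yl comes closest by name to the 3,4-dihydroxy-5-(hydroxymethyl)oxolan-2-yl of compound 1, which gives 1490 nM, and that value is the only number available as an anchor.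

The expected step is a step that the limit leaves unreadable from compound 3 to compound 4, with no shift beyond the scatter expected and no direction that can be stated. For compound 4 the estimate is 1500 nM, with an expected range of 600 nM to 4000 nM.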

Compound 4, half-maximal inhibitory concentration: 530 nM
Beside the measured number, compound 4's estimate is 2.8-fold (0.45 log units) above it; the measured number lies below the stated range.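

In this assay, the substituent on this aromatic nitrogen now has its first readable step: a 2.8-fold lower number from compound 1 to compound 4 (0.45 log units; beyond the scatter). Against the other two groups only floors can be stated, an at least 1.8-fold lower number from compound 3 to compound 4 (0.27 log units; that floor lies within the scatter) and an at least 1.8-fold lower number from compound 2 to compound 4 (0.27 log units; that floor lies within the scatter), so neither of these changes is shown to exceed the scatter. Compound 2 and compound 3 remain limits, and the steps among compounds 1, 2 and 3 cannot be read: the limit of > 1000 nM in this assay, at which 2 of the 4 values shown sit.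

On these data alone, the true positions of compound 2 and compound 3 stay open, so the order of the 2,3-dihydroxypropyl, (2,2-dimethyl-1,3-dioxolan-4-yl)methyl and 4-hydroxy-5-(hydroxymethyl)oxolan-2-yl groups cannot be set. Also open, as far as these compounds go, is how an amine or a carboxylic acid in place of the hydroxymethyl of the 4-hydroxy-5-(hydroxymethyl)oxolan-2-yl group would read in this assay.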